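Aryl exchange on the compound 1 scaffold

This account rests on a few compounds, and the source may have more. Where it says the series, first, only, none or still open, it means among the compounds named here.

Values in a functional assay on HCT-116 cells (Homo sapiens) for inhibition, read by sulforhodamine B assay, with a stated time of 48 h, tested at 50 uM (a higher number here means more inhibition of growth at the concentration tested, a lower number less inhibition of growth), for the measured compounds
- compound 1 `COc1cc(/C=C/C(=O)/C=C/c2cccc3ccccc23)ccc1OCc1cn(CCOc2cc(=O)oc3ccccc23)nn1` gives 83%
- compound 2 `COc1cc(/C=C/C(=O)/C=C/c2ccco2)ccc1OCc1cn(CCCOc2cc(=O)oc3ccccc23)nn1` gives 51%

Compound 1 stands higher of the two, and its gap to compound 2 lies beyond the scatter. Compound 3 `COc1cc(/C=C/C(=O)/C=C/c2cc(OC)c(OC)c(OC)c2)ccc1OCc1cn(CCOc2cc(=O)oc3ccccc23)nn1` carries 3,4,5-trimethoxyphenyl in place of naphthalen-1-yl on a double-bonded chain carbon bound to a double-bonded chain carbon. Among the measured compounds shown here, no measured step isolates this change, so its size remains uncertain. A modest fall in this assay is expected, with a number 13 percentage points lower from compound 1 to compound 3 (beyond the scatter) as the estimated step. For compound 3 the estimated value is 70% with an expected range from 50% to 88% in this series.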

Compound 3, percent growth inhibition at one concentration: 89%
Beside the measured number, compound 3's estimate is 19 percentage points below it; measured number above the stated range.
By their numbers in this assay, from the lowest: compound 2; then compounds 1 and 3 (each within the scatter of the next).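

In this assay, exchanging naphthalen-1-yl for 3,4,5-trimethoxyphenyl on a double-bonded chain carbon bound to a double-bonded chain carbon gives a number 6 percentage points higher from compound 1 to compound 3 (within the scatter). This position therefore accepts both aryl groups without a resolved change in growth inhibition, although one group has two six-membered aromatic rings and no hydrogen-bond acceptors, while the other has one such ring and 3 hydrogen-bond acceptors. No measurement shown here bears on this result. On these data alone, whether an amine or a carboxylic acid at this position would keep the read-out remains open.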